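A few compounds are considered here, and "the series" means these few. Any claim that something is new, unique, unknown or untested is made for them only; others in the source may bear on it.

Compound 1 `C=CC(=O)N1CC[C@H](N2C(=O)N(Cc3ccccc3)Cc3cnc(Nc4ccc(N5CCN(C)CC5)cc4OC)nc32)C1` gives 107 ug/mL in a physicochemical assay for solubility, read by HPLC, in phosphate buffer, measured as thermodynamic solubility, with a stated time of 24 h, at pH 6.8; a higher number here means a more soluble compound, a lower number a less soluble compound. Compound 2 `C=CC(=O)N1CC[C@H](N2C(=O)N(C(C)C)Cc3cnc(Nc4ccc(N5CCN(C)CC5)cc4OC)nc32)C1` gives 2490 ug/mL.

Compound 1 stands lowest of the two numbers shown; the only measured step, a 23-fold higher number from compound 1 to compound 2 (1.37 log units; beyond the scatter), concerns the group on the other ring nitrogen and so does not bear directly on the change to compound 3 `C=CC(=O)NCCN1C(=O)N(Cc2ccccc2)Cc2cnc(Nc3ccc(N4CCN(C)CC4)cc3OC)nc21`, which is 2-((vinylcarbonyl)amino)ethyl in place of 1-(vinylcarbonyl)pyrrolidin-3-yl on an amide-type nitrogen in a ring. Among the measured compounds shown here, no measured step covers this exchange, so compound 1 is the only anchor. Compound 3 is therefore expected to stay near compound 1, with a 1.4-fold higher number from compound 1 to compound 3 (0.15 log units; within the scatter) not beyond the scatter, estimated at 150 ug/mL within 40 ug/mL to 500 ug/mL.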

Compound 3, solubility: 96.7 ug/mL
Beside the measured number, compound 3's estimate is 1.6-fold (0.19 log units) above it; low and high end bracket the measured number.
By their numbers in this assay, from the lowest: compounds 3 and 1 (each within the scatter of the next); then compound 2.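

In this assay, 2-((vinylcarbonyl)amino)ethyl in place of 1-(vinylcarbonyl)pyrrolidin-3-yl gives a 1.1-fold lower number from compound 1 to compound 3 (0.04 log units; within the scatter) and so leaves the two compounds indistinguishable. At this amide-type nitrogen, then, the five-membered ring and the defined stereocentre can go and a hydrogen-bond donor can come in without a readable shift in the number. No available evidence accounts for this result.

Going by these compounds, whether a longer chain between this nitrogen and the vinylcarbonyl amide, or an amine on that chain, would leave the number as unchanged remains open. Also open, on these data alone, is whether the same exchange would read alike with isopropyl in place of benzyl on the other ring nitrogen.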